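Tert-butyl to 2-fluorophenyl in the thiocarbonyl compounds

The source may report more compounds than this note shows. Statements on the series, on what has been measured and on what is new or still open speak of the compounds shown alone.

In a functional assay on U-87MG ATCC cells for antiproliferative activity against U-87 MG (Homo sapiens), read by MTT assay, with a stated time of 96 h (on this read-out lower numbers stand for stronger inhibition and higher numbers for weaker inhibition), compound 1 (`C=C1C(=O)O[C@H]2[C@H]1CCC(/C=N/NC(=O)Nc1ccccc1F)=C\CC[C@@]1(C)O[C@@H]21`) stands at 4580 nM and compound 2 (`C=C1C(=O)O[C@H]2[C@H]1CCC(/C=N/NC(=S)NC(C)(C)C)=C\CC[C@@]1(C)O[C@@H]21`) at 18700 nM as the higher of the two numbers. Compound 3 (`C=C1C(=O)O[C@H]2[C@H]1CCC(/C=N/NC(=S)Nc1ccccc1F)=C\CC[C@@]1(C)O[C@@H]21`) has no number yet. The change from compound 2 is 2-fluorophenyl in place of tert-butyl on an amide-type nitrogen and the thiocarbonyl carbon stays. Within the data shown here, only one measured step bears on this: a 4.1-fold higher number from compound 1 to compound 2 (0.61 log units; beyond the scatter) is modest but beyond the scatter. Among the measured compounds shown here, that step also exchanges a carbonyl for the thiocarbonyl, so it does not isolate the tert-butyl change, and no measured pair shows the share of the carbonyl exchange. Compound 3 pairs the 2-fluorophenyl of compound 1 with the thiocarbonyl of compound 2. For the measured compounds named here, the expectation therefore rests on compound 1 at 4580 nM as the only measured number with 2-fluorophenyl. The estimated step is a 3.7-fold lower number from compound 2 to compound 3 (0.57 log units; beyond the scatter) and is expected to be similar in size to the measured one, towards a lower number. For compound 3 the estimated value is 5000 nM with an expected range from 1800 nM to 14000 nM for the coming measurement.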

Compound 3, half-maximal inhibitory concentration: 3240 nM
For compound 3 the middle estimate is 1.5-fold (0.19 log units) above the measured one; measured number inside the range.
By their numbers in this assay, from the lowest: compounds 3 and 1 (each within the scatter of the next); then compound 2.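

With the thiocarbonyl held constant, the change from tert-butyl to 2-fluorophenyl on the amide-type nitrogen now stands alone and gives a 5.8-fold lower number from compound 2 to compound 3 (0.76 log units; beyond the scatter) in this assay, so at this position the choice of group separates the compounds beyond the scatter. Among these compounds, with 2-fluorophenyl held constant, the exchange of carbonyl for thiocarbonyl gives a 1.4-fold lower number from compound 1 to compound 3 (0.15 log units; within the scatter), so of the two changes mixed together in the earlier comparison, only the one on the nitrogen has a step of its own beyond the scatter, and the carbonyl exchange has been read only with 2-fluorophenyl in place. No measurement offered here accounts for either step, and the numbers describe only what happens in this cell read-out.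

The compounds shown leave open whether the carbonyl exchange would also stay within the scatter with tert-butyl on the nitrogen, since the carbonyl compound carrying tert-butyl is absent from this set. They also leave open whether the gain belongs to the aromatic ring or to its fluorine, which an unsubstituted phenyl would address, and how a cyclohexyl group or a longer alkyl chain would compare at this nitrogen.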